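Dropping One Trifluoromethyl: What to Expect for Growth Inhibition

This account rests on a few compounds, and the source may have more. Where it says the series, first, only, none or still open, it means among the compounds named here.

Of the compounds shown here, three have so far been tested in a functional assay on MOLT-4 cells (Homo sapiens) for inhibition, read by sulforhodamine B assay, with a stated time of 48 h; on this read-out lower numbers stand for stronger inhibition of growth and higher numbers for weaker inhibition of growth. Compound 1 `COc1cc(-c2nn(-c3cccc(NC(=O)c4ccc(Cl)c(C(F)(F)F)c4)c3)cc2-c2ccncc2)ccc1Cl` gives 5240 nM. For the measured compounds named here, compound 3 `COc1cc(-c2nn(-c3cccc(NC(=O)Nc4ccc(Cl)c(C(F)(F)F)c4)c3)cc2-c2ccncc2)ccc1Cl` gives 1020 nM, and the one measured step between neighbours, a 5.1-fold lower number from compound 1 to compound 3 (0.71 log units; beyond the scatter), shows how much a single change at the carbonyl carbon moved the number. Compound 2 `O=C(Nc1cccc(-n2cc(-c3ccncc3)c(-c3ccc(Cl)c(O)c3)n2)c1)Nc1cc(C(F)(F)F)cc(C(F)(F)F)c1` gives 1150 nM and stands second highest of the three numbers; compound 3 is its nearest neighbour and sits within the scatter of it, whereas compound 1 lies beyond the scatter with the higher number.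

Compound 4 `O=C(Nc1cccc(-n2cc(-c3ccncc3)c(-c3ccc(Cl)c(O)c3)n2)c1)Nc1cccc(C(F)(F)F)c1` is not yet measured. It differs from compound 2 in one place: hydrogen in place of trifluoromethyl on an aromatic carbon. Going by the values given here, no measured step concerns this part of the molecule; the only step available, the change at the carbonyl carbon, tells nothing about what removing a trifluoromethyl on the far aromatic ring does. Since compound 2 and compound 3 share the same carbonyl linkage and give numbers within the scatter of each other, the expectation rests on the loss of one small group alone, which is expected to leave the number close to where compound 2 stands, with perhaps a slight rise, as a 1.3-fold higher number from compound 2 to compound 4 (0.12 log units; within the scatter) expresses. Compound 4 is therefore estimated to give 1500 nM, expected between 700 nM and 3500 nM.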

Compound 4, concentration for 50% growth inhibition: 1920 nM
Compound 4: the middle estimate sits 1.3-fold (0.11 log units) below what was measured; low and high end bracket the measured number.
By their numbers in this assay, from the lowest: compounds 3, 2 and 4 (each within the scatter of the next); then compound 1.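

For the compounds shown here, replacing one trifluoromethyl with hydrogen in this assay gives a 1.7-fold higher number from compound 2 to compound 4 (0.22 log units; within the scatter), the first measured change on this aromatic ring of the urea compounds, and it stays within the usual variation between repeated measurements. Compound 2 and compound 4 therefore cannot be told apart in this test, so a trifluoromethyl at this position can give way to a single hydrogen atom, which brings no heavy atom, without a change that the read-out can resolve. This is a statement about one pair of compounds and one position, and no measurement available here helps to explain the result.

The compounds shown leave open whether the trifluoromethyl that remains on compound 4 can also be replaced by hydrogen without a clear change, and whether a methyl group, a nitrile or an amine at the vacated position would leave the number just as unmoved. They also leave open whether the same replacement would behave in the same way on a compound without the urea linkage, such as compound 1.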